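Removing one methoxy from a diaryl ketone aminothiazole

The source may report more compounds than this note shows. Statements on the series, on what has been measured and on what is new or still open speak of the compounds shown alone.

Measured compounds in a functional assay on CCRF-CEM cells (Homo sapiens) for antiproliferative activity, read by cell counting, with a stated time of 2 days; on this read-out higher numbers stand for weaker inhibition and lower numbers for stronger inhibition:
compound 1 `COc1ccc(C(=O)c2sc(Nc3ccccc3)nc2N)cc1OC` gives 6900 nM;
compound 2 `COc1ccc(C(=O)c2sc(Nc3ccc(Cl)cc3)nc2N)cc1` gives > 10000 nM, a limit of the assay;
compound 3 `Nc1nc(Nc2ccc(Cl)cc2)sc1C(=O)c1ccccc1` gives > 10000 nM, also a limit of the assay.

For the measured compounds named here, compound 1 holds the only real number; the other two values sit at the limit of > 10000 nM in this assay, at which 2 of the 3 values shown sit. The difference between the cores of compound 1 and compound 2 is not broken down here. From compound 2 to compound 3 the change is hydrogen in place of methoxy on an aromatic carbon, and the step it made, a step that the two limits leave unreadable from compound 2 to compound 3, stays hidden behind the two limits. Compound 4 `COc1cccc(C(=O)c2sc(Nc3ccccc3)nc2N)c1` differs from compound 1 by hydrogen in place of methoxy on an aromatic carbon: the same kind of change, here sitting ortho to a methoxy group, and read against a real number. Compound 1 at 6900 nM leaves little room, so compound 4 is expected at 12000 nM, between 4000 nM and 40000 nM. The expected step is a 1.7-fold higher number from compound 1 to compound 4 (0.24 log units; within the scatter), with a fair chance that only a limit is reported.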

Compound 4, half-maximal inhibitory concentration: 2300 nM
Estimate against measurement, compound 4: 5.2-fold (0.72 log units) above; the measured number lies below the stated range.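

In this assay, hydrogen in place of methoxy on an aromatic carbon, ortho to a methoxy group, gives a 3.0-fold lower number from compound 1 to compound 4 (0.48 log units; beyond the scatter). The same kind of change on the core of compound 2 cannot be read, so the data show the step on the core of compound 1 only and do not show whether it carries from one core to another. Compound 2 and compound 3 both stand at a limit of the assay, not at a number: the limit of > 10000 nM in this assay, at which 2 of the 4 values shown sit.

The compounds shown leave open what a hydroxyl, an ethoxy or an amine would give on the aromatic carbon where compound 1 carries the methoxy that compound 4 lacks. They also leave open whether this step would recur on a further core with real numbers at both ends.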